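This account rests on a few compounds, and the source may have more. Where it says the series, first, only, none or still open, it means among the compounds named here.

Measured so far in an ADME assay on MCF7 cells (Homo sapiens) for cytotoxicity, with a stated time of 72 h; on this read-out higher numbers stand for weaker inhibition and lower numbers for stronger inhibition:
Compound 1 `Oc1cccc(CNc2ncnc3c2ncn3C2CCCCO2)c1`: > 100000 nM
Compound 2 `Oc1cccc(CNc2ncnc3c2ncn3C2CCCO2)c1`: > 100000 nM

Both entries are limits of the assay, not numbers. Compound 2 therefore has no exact value, only the limit > 100000 nM. The unmeasured compound 3 `COc1cccc(CNc2ncnc3c2ncn3C2CCCO2)c1` differs from compound 2 in one place: methyl in place of hydrogen on an oxygen on an aromatic ring. In other words, 3-hydroxyphenyl becomes 3-methoxyphenyl.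

Among the measured compounds shown here, the only measured step, a step that the two limits leave unreadable from compound 1 to compound 2, is a different change, oxolan-2-yl in place of oxan-2-yl on an aromatic nitrogen. It offers no size to carry over. Both measured compounds sit together at one ceiling: the limit of > 100000 nM in this assay, at which 2 of the 2 values shown sit. With so little to go on, no clear step in either direction is expected in this assay. The expected outcome is a number no higher from compound 2 to compound 3 (the limit leaves the size open). For compound 3 the estimate is 100000 nM, with an expected range of 40000 nM to 150000 nM.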

Compound 3, half-maximal inhibitory concentration: > 100000 nM
Compound 3 gave a limit, no number; the forecaster's own chance of this, stated with the estimate: 80%; the middle value lies on the limit itself.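

Among the compounds shown here, compound 3, like compound 2, gives only a limit of the assay and not a number, so no step between these two compounds can be read: the limit of > 100000 nM in this assay, at which 3 of the 3 values shown sit. The compounds shown leave open how strongly any of them inhibits, and whether going from hydroxy to methoxy changes that at all.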